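Methoxy Enters the Aryl Ring of Compound 3

A few compounds are considered here, and "the series" means these few. Any claim that something is new, unique, unknown or untested is made for them only; others in the source may bear on it.

For the measured compounds named here, compound 3 `O=C1c2ccccc2S(=O)(=O)N1CCCCN1CCN(c2ccccc2)CC1` is the only member of this small set with a single number in an assay on isolated protein for binding affinity to D(4) dopamine receptor (Homo sapiens); on this read-out lower numbers stand for stronger inhibition and higher numbers for weaker inhibition; in it compound 3 gives 136 nM. Compound 1 `O=C1c2ccccc2S(=O)(=O)N1CCCCN1CCN(c2cccc(C(F)(F)F)c2)CC1` carries a trifluoromethyl group on the aryl ring, and in this assay compound 1 reaches only a limit, > 5000 nM, namely (the limit of > 5000 nM in this assay, at which 1 of the 3 values shown sits). Compound 2 `O=C1c2ccccc2S(=O)(=O)N1CCCCCCN1CCN(c2cccc(C(F)(F)F)c2)CC1` has a longer chain between the two ring systems, and for compound 2 this assay records "not determined" (no result reported). Going by the values given here, the one step that can be read, an at least 36-fold lower number from compound 1 to compound 3 (1.56 log units; beyond the scatter), shows that a group on that aryl ring can move the number a long way. Compound 4 `COc1ccccc1N1CCN(CCCCN2C(=O)c3ccccc3S2(=O)=O)CC1` differs from compound 3 by methoxy in place of hydrogen on an aromatic carbon. Among the compounds with values here, the measured step concerns a different group and so sets no direction for this change; it shows only that a change on this ring can be large. The author expects compound 4 to give about 40 nM, within 8 nM to 250 nM, which is an expected step of a 3.4-fold lower number from compound 3 to compound 4 (0.53 log units; beyond the scatter).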

Compound 4, inhibition constant: 79 nM
Estimate against measurement, compound 4: 2.0-fold (0.30 log units) below; the measured number falls inside the stated range.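

In this assay, methoxy on an aromatic carbon, ortho to a large group, gives a step that stays within the scatter: a 1.7-fold lower number from compound 3 to compound 4 (0.24 log units; within the scatter). So this position takes methoxy with no clear change, whereas the earlier step showed only that a group on this ring can move the number a long way, and 2-methoxyphenyl still stands far from 3-(trifluoromethyl)phenyl: an at least 63-fold lower number from compound 1 to compound 4 (1.80 log units; beyond the scatter). That large step starts from a limit of the assay and not from a number, the one held by compound 1: the limit of > 5000 nM in this assay, at which 1 of the 4 values shown sits.

Steps involving compound 2, with its longer chain, cannot be read. The compounds shown leave open whether chlorine or a hydroxyl group on the same aromatic carbon would behave as methoxy does, and what a longer chain would do with the 2-methoxyphenyl group in place.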